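This account rests on a few compounds, and the source may have more. Where it says the series, first, only, none or still open, it means among the compounds named here.

Going by the values given here, in an ADME assay on MT4 cells (Homo sapiens) for cytotoxicity, read by MTT assay, with a stated time of 96 h (a lower number here means that less compound is tolerated, a higher number that more compound is tolerated), compound 1 `CN1CCN(CC(=O)Nc2ccc(-c3nc4cc(C(F)(F)F)ccc4n3C)cc2)CC1` gives 22000 nM, and compound 2 `Cn1c(-c2ccc(NC(=O)CN3CCCC3)cc2)nc2cc(C(F)(F)F)ccc21` gives 16000 nM, the lowest of the two numbers; the only step, a 1.4-fold lower number from compound 1 to compound 2 (0.14 log units; within the scatter), keeps both within the scatter. Compound 3 `CC(=O)Nc1ccc(-c2nc3cc(C(F)(F)F)ccc3n2C)cc1` differs from compound 2 by hydrogen in place of pyrrolidin-1-yl on a saturated chain carbon bound to a carbonyl carbon. No measured step bears on this change; the one step shown swaps one amine for another and moves nothing beyond the scatter, so no guide exists for removing the amine entirely. Compound 3 is therefore expected to land near compound 2, with a 1.6-fold higher number from compound 2 to compound 3 (0.19 log units; within the scatter) as the estimated step. The estimate for compound 3 is 25000 nM, range 8000 nM to 80000 nM.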

Compound 3, half-maximal cytotoxic concentration: 15000 nM
Compound 3: middle estimate off by 1.7-fold (0.22 log units), on the high side; the measured number falls inside the stated range.
By their numbers in this assay, from the lowest: compounds 3, 2 and 1 (each within the scatter of the next).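

In this assay hydrogen in place of pyrrolidin-1-yl gives a 1.1-fold lower number from compound 2 to compound 3 (0.03 log units; within the scatter) and hydrogen in place of 4-methylpiperazin-1-yl gives a 1.5-fold lower number from compound 1 to compound 3 (0.17 log units; within the scatter) on the same saturated chain carbon bound to a carbonyl carbon. The earlier step compared only one amine with another; now, with neither amine present, the number still stays within the scatter of both amine compounds. No measurement at hand accounts for this reading.

Going by these compounds, whether a carboxylic acid or a longer chain at this carbon would move the number beyond the scatter stays open. Also open, on these data alone, is whether the same reading holds with a nitrile in place of trifluoromethyl on the shared core.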